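Swapping the ring on the triazole nitrogen of compound 1

The source may hold more compounds than are shown below. What is called first, only, known or untested is meant among the compounds shown, and "the series" means these compounds.

In a functional assay on PC-12 cells (Rattus norvegicus) for cytotoxicity, read by MTT assay, with stated times of 2 h and 24 h, tested at 1 uM (on this read-out lower numbers stand for a weaker effect and higher numbers for a stronger effect at the one concentration tested), compound 1, with the structure `Oc1cc(C(F)(F)F)ccc1-c1nc(-c2ccccc2O)n(-c2ccc(Br)cc2)n1`, gives 69.4%. Two close relatives share its core and differ only in the group on one aromatic carbon: compound 2, `COc1ccc(-n2nc(-c3ccc(C(F)(F)F)cc3O)nc2-c2ccccc2O)cc1`, gives 69%, and compound 3, `N#Cc1ccc(-n2nc(-c3ccc(C(F)(F)F)cc3O)nc2-c2ccccc2O)cc1`, gives 66.6%. On the numbers alone compound 1 stands highest of the three, yet each gap to it is small: a number 0.4 percentage points lower from compound 1 to compound 2 (within the scatter), a number 2.8 percentage points lower from compound 1 to compound 3 (within the scatter), and between the other two a number 2.4 percentage points lower from compound 2 to compound 3 (within the scatter).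

Compound 4, `Oc1cc(C(F)(F)F)ccc1-c1nc(-c2ccccc2O)n(-c2ccccc2C(F)(F)F)n1`, is not yet measured. It differs from compound 1 by 2-(trifluoromethyl)phenyl in place of 4-bromophenyl on an aromatic nitrogen. Among the measured compounds shown here, the three measured steps all alter the same aromatic ring that sits on that nitrogen, and none of them moved the read-out beyond the scatter; they are the only guide available. The change in compound 4 is larger in kind, replacing a bromo-bearing ring with one carrying trifluoromethyl, but nothing measured suggests the read-out is sensitive to what this ring carries.

The expected step is therefore a number 2.4 percentage points lower from compound 1 to compound 4 (within the scatter), that is, no change beyond the scatter. Compound 4 is estimated to give 67%, within a range from 55% to 78%.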

Compound 4, a percentage reported as activity, at one concentration (the size of the read-out at that concentration, not a potency): 71%
Compound 4: the middle estimate sits 4 percentage points below what was measured; low and high end bracket the measured number.
By their numbers in this assay, from the lowest: compounds 3, 2, 1 and 4 (each within the scatter of the next).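

The three earlier rings, 4-bromophenyl, 4-methoxyphenyl and 4-cyanophenyl, all carry their group at the ring place numbered 4, whereas 2-(trifluoromethyl)phenyl changes both the group and its place on the ring. Even so, this assay shows a number 1.6 percentage points higher from compound 1 to compound 4 (within the scatter) for this exchange, so a change of both kinds at once on this aromatic nitrogen still stays within the usual variation. The same holds against the other two rings, with a number 2 percentage points higher from compound 2 to compound 4 (within the scatter) when it replaces 4-methoxyphenyl and a number 4.4 percentage points higher from compound 3 to compound 4 (within the scatter) when it replaces 4-cyanophenyl, and no measurement here offers an explanation for this flat result.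

As far as these compounds go, all four compounds keep a phenyl ring bearing a single group on this nitrogen, so it remains open whether a ring carrying an amine or a carboxylic acid, or a butyl chain in place of the ring, would move the number beyond the scatter. Since compound 4 changes the group and its place together, 4-(trifluoromethyl)phenyl would be needed to compare the two places directly with the same group.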